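Nitro to Amino: Expected Cytotoxicity of Compound 3

The source may hold more compounds than are shown below. What is called first, only, known or untested is meant among the compounds shown, and "the series" means these compounds.

Compound 1, `Cc1cc(NC(=O)Nc2cccc(Cl)c2)c2ccccc2n1`: 21000 nM
Compound 2, `Cc1cc(NC(=O)Nc2ccccc2[N+](=O)[O-])c2ccccc2n1`: > 25000 nM

Of the compounds shown here, two built on a shared core have been measured in an ADME assay on HEK293 cells (Homo sapiens) for cytotoxicity, with a stated time of 72 h; a lower number here means that less compound is needed, a higher number that more compound is needed for the effect. Compound 1 gives 21000 nM, so it needs a high concentration before cells are affected. For compound 2 the assay reports only a limit, > 25000 nM, which is the edge of what the test can read rather than a number. That limit is where one of the two values sits (the limit of > 25000 nM in this assay, at which 1 of the 2 values shown sits). Compound 2 therefore stands at the weak end of what has been seen so far.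

Compound 3, `Cc1cc(NC(=O)Nc2ccccc2N)c2ccccc2n1`, has not yet been measured. It differs from compound 2 in a single place: amino in place of nitro on an aromatic carbon. For the measured compounds named here, no step between two measured compounds is recorded, so the size of the change can only be guessed. Both measured compounds are weak, and the step of a number no higher from compound 2 to compound 3 (the limit leaves the size open) is expected to be none beyond the usual scatter. Compound 3 is expected to give about 25000 nM, within a range from 10000 nM to 60000 nM, with a fair chance that only a limit is reported again.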

Compound 3, half-maximal effective concentration: > 25000 nM
Compound 3: a limit, no number; the forecaster's own chance of this, stated with the estimate: 55%; the middle value sits exactly at the limit.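

In this assay compound 3 gives > 25000 nM, a limit and not a number, so amino on this aromatic carbon, ortho to a large group, reaches the edge of the test just as nitro does. Both ends of the change from nitro to amino are limits, so the size of that step cannot be read, and the results now gather at one edge: the limit of > 25000 nM in this assay, at which 2 of the 3 values shown sit. Putting 2-aminophenyl in place of 3-chlorophenyl gives an at least 1.1-fold higher number from compound 1 to compound 3 (0.07 log units; that floor lies within the scatter), so no real difference between these two compounds is shown.

Going by these compounds, how far compound 2 and compound 3 truly lie past the limit remains open, as does whether they differ from each other at all. A carboxylic acid or a methoxy group at this same place might or might not give a readable number.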